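The source may report more compounds than this note shows. Statements on the series, on what has been measured and on what is new or still open speak of the compounds shown alone.

Measured compounds:
compound 1 `CSc1ccc2nc(C)cc(OCC(=O)Nc3cc(C)cc(C)c3)c2c1` gives 6.42 in a physicochemical assay for lipophilicity, read by HPLC, in phosphate buffer, measured as chromatographic lipophilicity, at pH 7.4; a lower number here means a more polar compound, a higher number a more lipophilic compound
compound 2 `Cc1cc(C)cc(NC(=O)COc2cc(C)nc3ccc(C(F)(F)F)cc23)c1` gives 6.67 in this assay
compound 3 `COc1ccc2nc(C)cc(OCC(=O)Nc3ccccc3)c2c1` gives 4.28 in this assay

Compound 3 stands lowest of the three measured numbers; compound 1 lies nearest to it and compound 2 furthest, and both gaps are far beyond the scatter. Compound 4 `COc1ccc2nc(C)cc(OCC(=O)Nc3cc(C)c(F)c(C)c3)c2c1` has not yet been measured. It differs from compound 3 in one place: 4-fluoro-3,5-dimethylphenyl in place of phenyl on an amide-type nitrogen.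

Among the measured compounds shown here, only one measured step exists, and it concerns a different position on the shared core: a number 0.25 log units higher from compound 1 to compound 2 (within the scatter). It therefore says nothing direct about the change from compound 3 to compound 4. Compounds 1 and 2 each carry a dimethyl-substituted anilide ring and sit far higher than compound 3, but they also differ from compound 3 elsewhere, so their values cannot be read as a step for this change alone. A rise is nevertheless expected, since two methyl groups and a fluorine enter and nothing polar leaves. The expected step is a number 1.22 log units higher from compound 3 to compound 4 (beyond the scatter). Compound 4 is estimated at 5.5, with a likely range from 4.9 to 6.1.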

Compound 4, distribution coefficient: 5.5
For compound 4 middle estimate and measured number coincide at the digits printed; the range from low to high includes it.
By their numbers in this assay, from the lowest: compound 3; then compound 4; then compounds 1 and 2 (each within the scatter of the next).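

In this assay, among the compounds shown here, the exchange of phenyl for 4-fluoro-3,5-dimethylphenyl on the amide-type nitrogen gives a number 1.22 log units higher from compound 3 to compound 4 (beyond the scatter) and so provides the first reading of this position with only that one place changed. Compound 1 and compound 2 also carry a substituted ring there, but they differ from compound 3 elsewhere and could not show what this exchange does alone. Nothing available explains why the number moves this far.

On these data alone, the new ring brings two methyl groups and a fluorine together, so the share of each in the step stays unknown. Also open is where the number would land with an amine or a carboxylic acid on this ring, since every ring shown here carries only carbon-based groups or fluorine, or nothing at all.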